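The source may report more compounds than this note shows. Statements on the series, on what has been measured and on what is new or still open speak of the compounds shown alone.

Measured compounds in an ADME assay on microsomes from liver (Mus musculus) for metabolic stability; on this read-out lower numbers stand for a shorter-lived compound and higher numbers for a longer-lived compound:
- compound 1 `CC(C)C(c1ccc(-c2ccc3cccc(F)c3c2)[nH]c1=O)N1CCN/C1=N\C#N` gives 0.207 h
- compound 2 `CC(C)C(c1ccc(-c2ccc3cccc(F)c3c2)[nH]c1=O)N1CCCCS1(=O)=O` gives 0.0733 h
- compound 3 `CC(C)C(c1cnc(N)s1)c1ccc(-c2ccc3cccc(F)c3c2)[nH]c1=O` gives 0.08 h

Compound 3 holds the second highest of the three numbers in this assay. Its nearest neighbour is compound 2, the two lying within the scatter of each other, while compound 1 stands furthest away, a step described as a 2.6-fold lower number from compound 1 to compound 3 (0.41 log units; beyond the scatter). The three compounds share one core and differ only in the group carried on a saturated chain carbon bound to an aromatic carbon and a saturated chain carbon, so every recorded step bears on that one position.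

Compound 4 `Cc1c[nH]c(C(c2ccc(-c3ccc4cccc(F)c4c3)[nH]c2=O)C(C)C)n1` has not yet been measured in this assay. It differs from compound 3 in one place: 4-methyl-1H-imidazol-2-yl in place of 2-amino-1,3-thiazol-5-yl on a saturated chain carbon bound to an aromatic carbon and a saturated chain carbon.

The steps that inform this change are a 2.6-fold lower number from compound 1 to compound 3 (0.41 log units; beyond the scatter), a 2.8-fold lower number from compound 1 to compound 2 (0.45 log units; beyond the scatter) and a 1.1-fold higher number from compound 2 to compound 3 (0.04 log units; within the scatter). Two swaps at this position moved the number modestly downward from compound 1, and the swap between compound 2 and compound 3 stayed within the scatter. The imidazole of compound 4 has no measured counterpart among these three compounds, so the direction of its step cannot be read from them.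

Compound 4 is therefore expected to land near compound 3, at an estimated 0.09 h with a range from 0.04 h to 0.2 h, a step of a 1.1-fold higher number from compound 3 to compound 4 (0.05 log units; within the scatter) that is expected to stay within the scatter.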

Compound 4, half-life: < 0.0667 h
Compound 4 was reported as a limit; the forecaster's own chance of this, stated with the estimate: 5%; middle value at least 1.3-fold (0.13 log units) away from the limit.
By their numbers in this assay, from the lowest: compounds 2 and 3 (each within the scatter of the next); then compound 1. At a limit, below all of these: compound 4.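

In this assay compound 4 is reported only as a limit, and it is the one compound shown that sits there: the limit of < 0.0667 h in this assay, at which 1 of the 4 values shown sits. Taken from compound 3, the change of 2-amino-1,3-thiazol-5-yl to 4-methyl-1H-imidazol-2-yl gives an at least 1.1-fold lower number from compound 3 to compound 4 (0.07 log units; that floor lies within the scatter), and the step from compound 2 reads an at least 1.0-fold lower number from compound 2 to compound 4 (0.04 log units; that floor lies within the scatter), so neither step can yet be told apart from the scatter. Among the compounds shown here, only the step from compound 1 is clear, at an at least 3.1-fold lower number from compound 1 to compound 4 (0.49 log units; beyond the scatter), which makes compound 4 the third group at this position, after those of compound 2 and compound 3, to stand beyond the scatter from compound 1, leaving the group of compound 1 as the only one of the four that holds a clearly higher number.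

On these data alone, how far compound 4 lies past its limit stays open, and with it the true size of all three steps. Also open, as far as these compounds go, is what a plain imidazol-2-yl without the methyl, or an open-chain urea, would give on this saturated chain carbon, and whether any such group would match or pass compound 1.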